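Swapping an amine substituent on a corticotropin-releasing factor ligand

A few compounds are considered here, and "the series" means these few. Any claim that something is new, unique, unknown or untested is made for them only; others in the source may bear on it.

Compound 1, with the structure `CCCCN(CC)Cc1c(C(F)(F)F)nc2n(-c3c(C)cc(C)cc3C)c(Cl)cn12`, is the starting point. Among the compounds with values here, in an assay on cells for displacement of a labelled ligand from corticotropin-releasing factor receptor 1 (Homo sapiens), with a stated time of 100 min (on this read-out lower numbers stand for stronger inhibition and higher numbers for weaker inhibition), compound 1 gives 78 nM, the second highest of the three numbers measured so far. Its closest neighbour is compound 3, `CCCCN(Cc1ccccc1)Cc1c(C(F)(F)F)nc2n(-c3c(C)cc(C)cc3C)c(Cl)cn12`, which in this assay gives 130 nM; that move is a 1.7-fold higher number from compound 1 to compound 3 (0.22 log units; within the scatter), a change of phenyl in place of methyl on a saturated chain carbon bound to the amine nitrogen. The furthest is compound 2, `C=CCN(CC=C)Cc1c(C(F)(F)F)nc2n(-c3c(C)cc(C)cc3C)c(Cl)cn12`, which gives 13 nM; that move is a 6.0-fold lower number from compound 1 to compound 2 (0.78 log units; beyond the scatter), where both chains on the amine nitrogen become allyl.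

Compound 4, `CCN(Cc1ccc(Cl)c(Cl)c1)Cc1c(C(F)(F)F)nc2n(-c3c(C)cc(C)cc3C)c(Cl)cn12`, differs from compound 1 as follows: 3,4-dichlorophenyl in place of propyl on a saturated chain carbon bound to an amine nitrogen. Within the data shown here, only the step from compound 1 to compound 3 bears directly on this, since it also places an aromatic ring on that same chain carbon, and its size stayed within the scatter. The step to compound 2 changes both chains at once and so says little here. Among the measured compounds shown here, the two extra chlorine atoms on the ring have no counterpart among the measured compounds.

The expectation for compound 4 is therefore a step of a 1.4-fold higher number from compound 1 to compound 4 (0.15 log units; within the scatter), not beyond the scatter, giving an estimated 110 nM with a range from 40 nM to 320 nM.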

Compound 4, inhibition constant: 580 nM
Estimate against measurement, compound 4: 5.3-fold (0.72 log units) below, and the stated range ends below it.
By their numbers in this assay, from the lowest: compound 2; then compounds 1 and 3 (each within the scatter of the next); then compound 4.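

Within the data shown here, exchanging the butyl chain for 3,4-dichlorobenzyl is the first change to give a higher number beyond the scatter in this assay (a 7.4-fold higher number from compound 1 to compound 4 (0.87 log units; beyond the scatter)). An aromatic ring on a chain at this amine nitrogen is therefore not always neutral: the other aromatic change, which keeps the butyl chain and puts an unsubstituted benzyl where the ethyl chain stood, stays within the scatter (a 1.7-fold higher number from compound 1 to compound 3 (0.22 log units; within the scatter)). No measurement shown here offers an explanation for the higher number seen with the 3,4-dichlorobenzyl chain.

Compound 3 and compound 4 differ in more than one place, in which chain is replaced and in the two chlorine atoms, so the compounds shown cannot tell whether the ring, the chlorine atoms or the choice of chain accounts for the change. A plain benzyl in place of butyl with the ethyl chain kept remains an open case, as does a benzyl carrying a methoxy group instead of the chlorine atoms.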